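A few compounds are considered here, and "the series" means these few. Any claim that something is new, unique, unknown or untested is made for them only; others in the source may bear on it.

Within the data shown here, in a functional assay on NCI-H460 cells (Homo sapiens) for cytotoxicity, read by MTT assay, with a stated time of 68 h (on this read-out lower numbers stand for stronger inhibition and higher numbers for weaker inhibition), compound 1 `O=C(Nc1cccc(-c2ccccc2C(F)(F)F)c1)C(Cl)Cl` gives 7550 nM and this is the only true number so far. Compound 2 `O=C(Nc1cccc(-c2cccc(NC(=O)C(Cl)Cl)c2)c1)C(Cl)Cl` stands at > 50000 nM which is a limit of the assay and not a number. Compound 1 therefore has no measured neighbour against which it can be ranked.

Compound 3 `O=C(Nc1cccc(-c2ccccc2Cl)c1)C(Cl)Cl` keeps the core of compound 1 and alters a single group. The change chloro in place of trifluoromethyl on an aromatic carbon is chloro in place of trifluoromethyl on an aromatic carbon, ortho to a large group. Among the measured compounds shown here, no measured pair of compounds shows what a swap of this kind does, so there is no direct precedent for the size of the step. The expectation starts from compound 1 at 7550 nM with the rest of the structure left as it is. In this assay no step beyond the usual scatter of repeated measurements is expected, and neither direction is favoured. The estimated step of a 1.1-fold higher number from compound 1 to compound 3 (0.03 log units; within the scatter) is correspondingly small. For compound 3 the estimated value is 8000 nM with an expected range from 3500 nM to 18000 nM across repeat measurements.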

Compound 3, half-maximal inhibitory concentration: > 50000 nM
Compound 3: no number, only a limit; the forecaster's own chance of this, stated with the estimate: 5%; at least 6.2-fold (0.79 log units) between middle value and limit.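

Among these compounds, compound 3 gives the first comparison in which a single group changes while the core of compound 1 stays the same: in this assay, putting chloro in place of trifluoromethyl on this aromatic carbon, ortho to a large group, gives an at least 6.6-fold higher number from compound 1 to compound 3 (0.82 log units; beyond the scatter). This shows that the group at this position matters for the read-out, and that chloro, with one heavy atom in place of four, does not act as an equal stand-in for trifluoromethyl here. The value of compound 3, > 50000 nM, is a limit of the assay and not a number, and it is not unique to this compound: the limit of > 50000 nM in this assay, at which 2 of the 3 values shown sit.

The compounds shown leave open whether trifluoromethyl is unusually favourable at this position or chloro is unusually poor, and a methyl group, a methoxy group or a plain hydrogen in the same place would help to separate those two readings. They also leave open the true size of the step, which has a lower bound but no upper one.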